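The compounds below may be only part of what the source reports. "The series", "measured", "known", "first", "only" and "open" are said of these compounds alone.

Among the compounds with values here, compound 2 `Cc1ccc(S(=O)(=O)/N=C(/CCNC2=CC(=O)c3ccccc3C2=O)Nc2ccc(Cl)cc2Cl)cc1` gives 17000 nM in a functional assay on MCF7 cells (Homo sapiens) for cytotoxicity, read by MTT assay, with a stated time of 48 h (a higher number here means a weaker inhibitor, a lower number a stronger inhibitor), the highest of the two numbers so far; compound 1 `Cc1ccc(S(=O)(=O)/N=C(/CCNC2=CC(=O)c3ccccc3C2=O)Nc2ccc(F)cc2)cc1` gives 4260 nM. Within the data shown here, the only measured step, a 4.0-fold higher number from compound 1 to compound 2 (0.60 log units; beyond the scatter), swaps one aromatic group for another. Among the measured compounds shown here, compound 3 `Cc1ccc(S(=O)(=O)/N=C(/CCNC2=CC(=O)c3ccccc3C2=O)NC(C)C)cc1` differs from compound 2 by isopropyl in place of 2,4-dichlorophenyl on an amine nitrogen, an aromatic ring giving way to a short branched chain, which no measured step directly covers. The expected step is a 2.8-fold lower number from compound 2 to compound 3 (0.45 log units; beyond the scatter), leaning toward the lower number of compound 1 with wide uncertainty. Compound 3 is therefore estimated at 6000 nM, with a range of 1500 nM to 25000 nM in this assay.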

Compound 3, half-maximal inhibitory concentration: 16500 nM
Compound 3: middle estimate off by 2.8-fold (0.44 log units), on the low side, and the stated range covers the measured number.
By their numbers in this assay, from the lowest: compound 1; then compounds 3 and 2 (each within the scatter of the next).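

Putting isopropyl in place of 2,4-dichlorophenyl on this amine nitrogen gives a 1.0-fold lower number from compound 2 to compound 3 (0.01 log units; within the scatter) in this assay so here the aromatic ring and both chlorines can go without the number moving. Compound 1 alone stands apart, with a 3.9-fold higher number from compound 1 to compound 3 (0.59 log units; beyond the scatter) and so an aromatic ring at this position is not enough to give the lower number, as compound 2 shows. No measured evidence accounts for this. Still open, as far as these compounds go, is whether a plain phenyl or a cyclohexyl group on this nitrogen would sit with compound 1 or with compound 3.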